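The source may report more compounds than this note shows. Statements on the series, on what has been measured and on what is new or still open speak of the compounds shown alone.

Measured so far in an ADME assay (Canis lupus familiaris, strain Beagle) for pharmacokinetics; on this read-out higher numbers stand for wider distribution into tissues and lower numbers for narrower distribution:

compound 1 `CCn1c(-c2cnc(C)nc2)nc2c(N[C@H]3CCN(C(=O)C4CCC4)C3)ncnc21`: 2.3 L/kg
compound 2 `CCn1c(-c2ccc(C(F)(F)F)nc2)nc2c(O[C@H]3CCN(C(=O)N4CC(OC)C4)C3)ncnc21`: 1.7 L/kg
compound 3 `CCn1c(-c2cnc(C)nc2)nc2c(N[C@H]3CCN(C(=O)[C@H]4C[C@@H](OC)C4)C3)ncnc21`: 2 L/kg

Compound 2 stands lowest of the three numbers in this assay, but its gap to compound 3 and its gap to compound 1 both lie within the scatter, so the three compounds are not separable on this read-out.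

Compound 4 `CCn1c(-c2ccc(C(F)(F)F)nc2)nc2c(O[C@H]3CCN(C(=O)C4CCOC4)C3)ncnc21` is the next member. It differs from compound 2 by oxolan-3-yl in place of 3-methoxyazetidin-1-yl on a carbonyl carbon.

Within the data shown here, only one step between measured compounds is available, a 1.2-fold lower number from compound 1 to compound 3 (0.06 log units; within the scatter). It touches the same amide region of the shared core, and it lay within the scatter. Among the measured compounds shown here, it is not the same kind of change as the one from compound 2 to compound 4, and no measured pair swaps the ring on the carbonyl carbon, so it bears on the new step only loosely. With nothing in the measured steps pointing to a move beyond the scatter, the expectation is a step of a 1.1-fold higher number from compound 2 to compound 4 (0.02 log units; within the scatter), that is, no change beyond the scatter in this assay.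

Compound 4 is therefore estimated at 1.8 L/kg, with a range from 1.1 L/kg to 2.9 L/kg.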

Compound 4, volume of distribution: 1.6 L/kg
The estimate for compound 4 lay 1.1-fold (0.05 log units) above the measured number; low and high end bracket the measured number.
By their numbers in this assay, from the lowest: compounds 4, 2, 3 and 1 (each within the scatter of the next).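

In this assay, oxolan-3-yl in place of 3-methoxyazetidin-1-yl on a carbonyl carbon gives a 1.1-fold lower number from compound 2 to compound 4 (0.03 log units; within the scatter), so this exchange of a four-membered ring carrying a nitrogen for a five-membered ring without one does not separate the two compounds. The earlier step covered only methoxy in place of hydrogen on a saturated ring carbon, whereas this pair replaces the whole group on the carbonyl carbon and still stays within the scatter. No supporting data bear on why the read-out holds here.

The compounds shown leave open whether a group of another kind on this carbonyl carbon, such as a dimethylamino group or a ring bearing a carboxylic acid, would move the read-out beyond the scatter. Going by these compounds, it also remains open whether the same exchange would behave alike on the core of compound 1.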